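From Cyano to Methylsulfonyl on an Aromatic Carbon

The source may report more compounds than this note shows. Statements on the series, on what has been measured and on what is new or still open speak of the compounds shown alone.

Of the compounds shown here, two sharing one core have been measured in a physicochemical assay for lipophilicity, read by HPLC, at pH 7.4; a lower number here means a more polar compound, a higher number a more lipophilic compound. Compound 1 `CS(=O)(=O)c1ccc(-c2cnc(N)c(-c3ccc(C(F)(F)F)cc3)c2)cc1` gives 3.4, and compound 2 `CS(=O)(=O)c1ccc(-c2cnc(N)c(-c3ccc(C#N)cc3)c2)cc1` gives 2.4. Compound 2 therefore holds the lower of the two numbers.

Compound 3 `CS(=O)(=O)c1ccc(-c2cnc(N)c(-c3ccc(S(C)(=O)=O)cc3)c2)cc1` keeps the same core but carries methylsulfonyl in place of cyano on an aromatic carbon, para to a large group: methylsulfonyl in place of cyano on an aromatic carbon. For the measured compounds named here, only one measured step bears on this change, and it does so indirectly. That step, where cyano took the place of trifluoromethyl on the same aromatic carbon, is a number 1.00 log units lower from compound 1 to compound 2 (beyond the scatter). Going by the values given here, it involves a different pair of groups, and no measured compound shows methylsulfonyl at this place. The expectation in this assay is therefore a further move in the same direction, smaller than that step and possibly not much beyond the scatter. The expected step is a number 0.40 log units lower from compound 2 to compound 3 (beyond the scatter). For compound 3 the estimated value is 2, with an expected range from 1.6 to 2.4.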

Compound 3, distribution coefficient: 2
Beside the measured number, compound 3's estimate shows no gap at the digits printed, and the stated range covers the measured number.
By their numbers in this assay, from the lowest: compound 3; then compound 2; then compound 1.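

With methylsulfonyl, this aromatic carbon now has three measured groups on the shared core, and in this assay the change from cyano gives a number 0.40 log units lower from compound 2 to compound 3 (beyond the scatter) and so extends the downward run that began with cyano replacing trifluoromethyl. The number fell even though methylsulfonyl, with 4 heavy atoms, is the larger of the two groups exchanged here, against 2 heavy atoms for cyano, so in this pair a larger group did not bring a higher number. Taken from the other end, the replacement of trifluoromethyl by methylsulfonyl gives a number 1.40 log units lower from compound 1 to compound 3 (beyond the scatter) and sets the widest span yet seen at this place, with no compound among the three going against the order of trifluoromethyl, cyano and methylsulfonyl.

From the compounds shown here alone, whether an amine or a carboxylic acid on this same aromatic carbon would fall below compound 3 stays open, as does whether this order of the three groups would hold on any other core. Nothing shown here explains the size of either step.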